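This account rests on a few compounds, and the source may have more. Where it says the series, first, only, none or still open, it means among the compounds named here.

In an ADME assay on MT4 cells (Homo sapiens) for cytotoxicity, read by MTT assay (a higher number here means that more compound is tolerated, a lower number that less compound is tolerated), three compounds of one family have been measured and a fourth has not. Compound 1 has the structure `COc1ccc(C(=O)CSc2nc(Cc3c(F)cccc3Cl)c(C(C)C)c(=O)[nH]2)cc1`. For compound 1 the result is a limit of the assay, > 11000 nM. Compound 2, `CCC(C)c1c(Cc2c(F)cccc2Cl)nc(SCC(=O)c2ccc(OC)cc2)[nH]c1=O`, differs from compound 1 by methyl in place of hydrogen on a saturated chain carbon, two bonds along the chain from an aromatic carbon; in this assay compound 2 gives 40000 nM. Because compound 1 is known only through (the limit of > 11000 nM in this assay, at which 1 of the 3 values shown sits), the step that the limit leaves unreadable from compound 1 to compound 2 cannot be read in size.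

Compound 3, `CCc1c(Cc2c(F)cccc2F)nc(SCC(=O)c2ccccc2)[nH]c1=O`, has a different core, and how its core differs from that of compound 1 is not broken down here. In this assay compound 3 gives 56000 nM, and this lies within the usual scatter of what compound 2 gives, although the two compounds differ at more than one place.

Compound 4, `CC(C)c1c(Cc2c(F)cccc2F)nc(SCC(=O)c2ccccc2)[nH]c1=O`, is not yet measured. It differs from compound 3 by methyl in place of hydrogen on a saturated chain carbon bound to an aromatic carbon and a saturated chain carbon. This is the same kind of change as that from compound 1 to compound 2, but the place is not identical: there the methyl enters on a saturated chain carbon two bonds along the chain from an aromatic carbon, here on a saturated chain carbon bound to an aromatic carbon and a saturated chain carbon. Since the earlier step that the limit leaves unreadable from compound 1 to compound 2 is unreadable, the expectation rests on the value of compound 3, 56000 nM, and on compound 2 and compound 3 giving values within the scatter of each other despite their several differences. The expected step is a 1.2-fold lower number from compound 3 to compound 4 (0.09 log units; within the scatter), small in size. Compound 4 is therefore expected to give about 45000 nM in this assay, likely between 18000 nM and 110000 nM.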

Compound 4, half-maximal cytotoxic concentration: > 60000 nM
Compound 4: no number, only a limit; the forecaster's own chance of this, stated with the estimate: 25%; middle value at least 1.3-fold (0.12 log units) from the limit.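

In this assay compound 4 gives > 60000 nM, which is a limit of the assay and not a number. Among these compounds, the new step reads an at least 1.0-fold higher number from compound 3 to compound 4 (0.02 log units; that floor lies within the scatter), so on this core, swapping ethyl for isopropyl gives no sign that less compound is tolerated, but the floor does not separate the two compounds, and the real size of the step remains unknown. This says little about carrying the change from one core to another, since one of the two steps has no size to compare with: the related methyl step on the core of compound 1, which enters at a different place, cannot be read, because compound 1 is known only through a limit: the limit of > 11000 nM in this assay, at which 1 of the 4 values shown sits.

The compounds shown leave open what a group of another kind, such as an amine or a carboxylic acid, would give in this assay in place of the ethyl or isopropyl, as all four compounds carry only saturated carbon chains there. They also leave open whether the methyl change has the same size on both cores, a question that needs a number in place of each limit.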